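The source may hold more compounds than are shown below. What is called first, only, known or untested is meant among the compounds shown, and "the series" means these compounds.

Series notes. Compounds 1 to 3 share the same core and differ only in the groups on the second aryl ring. Compound 1 `COC1c2ccc(C#Cc3cc(Cl)ccc3OCC(=O)O)cc2S(=O)(=O)C1(C)C` gives 21 nM in an assay on CHO cells for displacement of a labelled ligand from prostaglandin D2 receptor 2 (Homo sapiens), read by scintillation counting; a lower number here means a stronger inhibitor, a higher number a weaker inhibitor. Compound 2 `CCS(=O)(=O)c1ccc(C)c(C#Cc2cc(Cl)ccc2OCC(=O)O)c1` gives 8.6 nM in this assay, and compound 3 `CC(C)c1ccc(S(C)(=O)=O)cc1C#Cc1cc(Cl)ccc1OCC(=O)O` gives 4.6 nM. Among these three numbers compound 2 stands second highest: its nearest neighbour is compound 3, a gap that lies within the scatter of repeated measurements, while the gap to compound 1 lies beyond it. Compound 4 `Cc1ccc(S(=O)(=O)NC(C)(C)C)cc1C#Cc1cc(Cl)ccc1OCC(=O)O` is not yet measured in this assay. It differs from compound 2 in one place: (tert-butyl)amino in place of ethyl on a sulfonyl sulfur. Cut one bond further out, the change reads ethylsulfonyl to (tert-butyl)sulfamoyl; the rest of the structure is unchanged. Within the data shown here, no measured pair in the set isolates a change at the sulfonyl sulfur, so the size of this step has no direct precedent here. The three measured sulfones span only a modest range, and the sulfonyl group itself is retained in compound 4. The expectation is a step of a 1.4-fold higher number from compound 2 to compound 4 (0.14 log units; within the scatter) that stays within the scatter, if anything toward a higher number. Compound 4 is therefore estimated at 12 nM, with a range from 4 nM to 40 nM.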

Compound 4, inhibition constant: 5 nM
Estimate against measurement, compound 4: 2.4-fold (0.38 log units) above; low and high end bracket the measured number.
By their numbers in this assay, from the lowest: compounds 3, 4 and 2 (each within the scatter of the next); then compound 1.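

In this assay, among these compounds, the exchange at the sulfonyl sulfur gives the first direct reading for this position: a 1.7-fold lower number from compound 2 to compound 4 (0.24 log units; within the scatter). Among the compounds shown here, the position therefore accepts (tert-butyl)amino, with 5 heavy atoms and 1 hydrogen-bond donor, in place of ethyl, with 2 heavy atoms and no donor, without a change that can be told from the scatter, which the differences among the earlier compounds could not show. Nothing measured here speaks to what lies behind this flat step, and this single pair sets no trend for the position.

Still open, going by these compounds, is whether the flat result belongs to the nitrogen on the sulfonyl sulfur or to the branched tert-butyl group, which an unsubstituted amino group, a methylamino group or a dimethylamino group at the same place would help to separate. Also open, on these data alone, is how far the position stretches to a ring amine such as morpholine or piperidine, or to a carboxylic acid-bearing chain on the sulfur.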